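The source may hold more compounds than are shown below. What is called first, only, known or untested is meant among the compounds shown, and "the series" means these compounds.

Compound 2 `O=C(CNC(=O)c1nn(-c2ccccc2)c(=O)c2ccccc12)Nc1nc2ccc(C(F)(F)F)cc2s1` stands lowest of the two numbers in an assay on L cells for inhibition of Protein-serine O-palmitoleoyltransferase porcupine (Mus musculus), read by reporter gene assay, with a stated time of 24 h (a lower number here means that less compound is needed, a higher number that more compound is needed for the effect), giving 110 nM, while compound 1 `O=C(CNC(=O)c1nn(-c2ccccc2)c(=O)c2ccccc12)Nc1nc2ccccc2s1` gives 2600 nM. Going by the values given here, the only measured step, a 24-fold lower number from compound 1 to compound 2 (1.37 log units; beyond the scatter), is large. Compound 3 `O=C(CNC(=O)c1nn(-c2ccccc2)c(=O)c2ccccc12)Nc1nc2ccc(Cl)cc2s1` differs from compound 2 by chloro in place of trifluoromethyl on an aromatic carbon. Among the compounds with values here, no measured step concerns chloro itself; the step from compound 1 to compound 2 shows only that a group in place of hydrogen at that carbon lowers the number strongly. For compound 3 a modest rise relative to compound 2 is expected, a 2.3-fold higher number from compound 2 to compound 3 (0.36 log units; beyond the scatter). Compound 3 is estimated at 250 nM, within 80 nM to 800 nM.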

Compound 3, half-maximal effective concentration: 30 nM
Beside the measured number, compound 3's estimate is 8.3-fold (0.92 log units) above it, outside the stated range (below it).
By their numbers in this assay, from the lowest: compound 3; then compound 2; then compound 1.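

In this assay the single chlorine atom of chloro serves this aromatic carbon better than the four heavy atoms of trifluoromethyl, with a 3.7-fold lower number from compound 2 to compound 3 (0.56 log units; beyond the scatter) at this position. The full gain over hydrogen at the same carbon is an 87-fold lower number from compound 1 to compound 3 (1.94 log units; beyond the scatter) and shows that the lowering is not peculiar to trifluoromethyl. No measurement given here accounts for the order of chloro and trifluoromethyl.

From the compounds shown here alone, how fluoro, methoxy or an amine would fare at this carbon remains open. So does whether chloro would give a similar step on another carbon of this ring.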